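The source may report more compounds than this note shows. Statements on the series, on what has been measured and on what is new or still open speak of the compounds shown alone.

Compound 1: `Cc1ccc(-c2noc(-c3ccc(C(=O)C(F)(F)F)s3)n2)cc1`, 860 nM
Compound 2: `O=C(c1ccc(-c2nc(Cc3cccs3)no2)s1)C(F)(F)F`, 170 nM
Compound 3: `O=C(c1ccc(-c2nc(-c3cccnc3)no2)s1)C(F)(F)F`, not yet measured

In an assay on isolated protein for inhibition of protein deacetylase HDAC6 (Homo sapiens) (a lower number here means a stronger inhibitor, a higher number a weaker inhibitor), compound 2 gives the lowest of the two numbers; compound 1 gives a higher one, and the step of a 5.1-fold lower number from compound 1 to compound 2 (0.70 log units; beyond the scatter) lies beyond the scatter. Compound 3 changes compound 2 by pyridin-3-yl in place of (thiophen-2-yl)methyl on an aromatic carbon. This change places a six-membered aromatic ring directly on the core, as in compound 1, where the ring sits directly on the core and the number is higher. For the measured compounds named here, only that one step bears on it, so the number for compound 3 is expected to rise, roughly a 2.9-fold higher number from compound 2 to compound 3 (0.47 log units; beyond the scatter). The estimate for compound 3 is 500 nM, within 150 nM to 1500 nM.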

Compound 3, half-maximal inhibitory concentration: 840 nM
For compound 3 the middle estimate is 1.7-fold (0.23 log units) below the measured one; the measured number falls inside the stated range.
By their numbers in this assay, from the lowest: compound 2; then compounds 3 and 1 (each within the scatter of the next).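

In this assay, pyridin-3-yl in place of (thiophen-2-yl)methyl gives a 4.9-fold higher number from compound 2 to compound 3 (0.69 log units; beyond the scatter). The other step, a 1.0-fold lower number from compound 1 to compound 3 (0.01 log units; within the scatter), shows that pyridin-3-yl and 4-methylphenyl, each a six-membered aromatic ring, read alike at this position, so compound 2 stands alone among the three with its five-membered ring on a one-carbon link. No evidence is available to explain these differences. The compounds shown leave open whether the link or the thiophene ring matters more. A benzyl group or a directly attached thiophen-2-yl group would help separate the two.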